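Swapping the aryl group on the shared core

The source may report more compounds than this note shows. Statements on the series, on what has been measured and on what is new or still open speak of the compounds shown alone.

Three compounds have numbers in a functional assay on KYSE-410 cells (Homo sapiens) for antiproliferative activity, read by MTT assay, with a stated time of 72 h (on this read-out lower numbers stand for stronger inhibition and higher numbers for weaker inhibition), and are set out here

Compound 1 `COc1ccc(-c2ccc3c(C(=O)Nc4cccc(F)c4)cc(=O)[nH]c3c2)cc1` gives 18000 nM
Compound 2 `O=C(Nc1cccc(F)c1)c1cc(=O)[nH]c2cc(-c3ccsc3)ccc12` gives 4300 nM
Compound 3 `O=C(Nc1cccc(F)c1)c1cc(=O)[nH]c2cc(-c3cccnc3F)ccc12` gives 11600 nM

Compound 3 cannot be separated from one of its neighbours (a 1.6-fold lower number from compound 1 to compound 3 (0.19 log units; within the scatter)) but stands clearly apart from the other (a 2.7-fold higher number from compound 2 to compound 3 (0.43 log units; beyond the scatter)). The next compound, compound 4 `O=C(Nc1cccc(F)c1)c1cc(=O)[nH]c2cc(-c3ccc(F)c(CO)c3)ccc12`, carries 4-fluoro-3-(hydroxymethyl)phenyl in place of 2-fluoropyridin-3-yl on an aromatic carbon. Among the measured compounds shown here, no measured step makes this exact exchange. The nearest guides are the other exchanges at the same place, and these are modest or smaller (a 4.2-fold lower number from compound 1 to compound 2 (0.62 log units; beyond the scatter)). For the measured compounds named here, compound 1, the only measured compound with a ring of carbon only at that place, gives 18000 nM, so a large gain is not expected from that ring. A small change within the scatter is expected (a 1.7-fold lower number from compound 3 to compound 4 (0.22 log units; within the scatter)). Compound 4 is estimated at 7000 nM in this assay, with an expected range from 2200 nM to 20000 nM.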

Compound 4, half-maximal inhibitory concentration: > 20000 nM
Compound 4: no number, only a limit; the forecaster's own chance of this, stated with the estimate: 5%; middle value at least 2.8-fold (0.45 log units) from the limit.
By their numbers in this assay, from the lowest: compound 2; then compounds 3 and 1 (each within the scatter of the next). At a limit, above all of these: compound 4.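

In this assay, compound 4 gives a limit and not a number: the limit of > 20000 nM in this assay, at which 1 of the 4 values shown sits. Among the compounds shown here, the 4-fluoro-3-(hydroxymethyl)phenyl group is the first at this position to carry a hydrogen-bond donor, and it brings no gain over thiophen-3-yl, with an at least 4.6-fold higher number from compound 2 to compound 4 (0.66 log units; beyond the scatter); compound 2 is thus also separated from this fourth group, although compound 3 shows that a ring with a hetero atom does not by itself match thiophen-3-yl. The steps of an at least 1.7-fold higher number from compound 3 to compound 4 (0.23 log units; that floor lies within the scatter) and an at least 1.1-fold higher number from compound 1 to compound 4 (0.04 log units; that floor lies within the scatter) rest on floors within the scatter, so they separate none of these groups.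

The compounds shown leave open whether the hydroxymethyl or the fluorine accounts for the result. They also leave open how a plain phenyl, or a phenyl bearing an aminomethyl or a carboxylic acid, would read at this position.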